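The source may report more compounds than this note shows. Statements on the series, on what has been measured and on what is new or still open speak of the compounds shown alone.

Measured so far:
Compound 1, `CCN(CC)c1ccc(N2C(=O)NC3(CSC4=C3C(=O)c3ncccc3C4=O)C2=O)cc1`: 50 nM
Compound 2, `CCc1ccc(N2C(=O)NC3(CSC4=C3C(=O)c3ncccc3C4=O)C2=O)cc1`: 1 nM

Both compounds share one core and differ only in the group on the six-membered aromatic ring of carbon only. For the measured compounds named here, in a functional assay on HT-29 cells (Homo sapiens) for antiproliferative activity, read by MTT assay, with a stated time of 96 h (a higher number here means a weaker inhibitor, a lower number a stronger inhibitor), compound 2 gives 1 nM, the lower of the two numbers, while compound 1 gives 50 nM; the move a 50-fold lower number from compound 1 to compound 2 (1.70 log units; beyond the scatter) is the only step measured here.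

Compound 3, `CC(C)(C)c1ccc(N2C(=O)NC3(CSC4=C3C(=O)c3ncccc3C4=O)C2=O)cc1`, is the next compound, differing from compound 2 by tert-butyl in place of ethyl on an aromatic carbon. Going by the values given here, the step from compound 1 to compound 2 does not speak directly to this change, since the group that leaves there, diethylamino, is unlike ethyl or tert-butyl; it shows only that the group at this position can shift the number strongly. Among the compounds with values here, with no directly comparable step measured, the expectation for compound 3 rests on compound 2 alone and carries a wide range. Compound 3 is expected to stay near compound 2, with a 3.0-fold higher number from compound 2 to compound 3 (0.48 log units; beyond the scatter), a step that could fall in either direction but is most likely a small rise. Compound 3 is therefore estimated at 3 nM, with a range from 0.7 nM to 15 nM.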

Compound 3, half-maximal inhibitory concentration: 150 nM
Compound 3: middle estimate off by 50-fold (1.70 log units), on the low side; measured number outside the range, above it.
By their numbers in this assay, from the lowest: compound 2; then compound 1; then compound 3.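

In this assay, this position proves far more sensitive than the earlier pair could show: a 150-fold higher number from compound 2 to compound 3 (2.18 log units; beyond the scatter) comes from swapping ethyl for tert-butyl, two groups made only of carbon, with no ring, no charge and no hydrogen-bond donor or acceptor. So a strong shift here does not need a nitrogen-bearing group like the diethylamino of compound 1, and the tert-butyl change moves the number even further than the diethylamino change did, with a 3.0-fold higher number from compound 1 to compound 3 (0.48 log units; beyond the scatter) placing compound 3 as the weakest of the three and compound 2 as the strongest, with its steps to both others beyond the scatter. Nothing available gives a measured reason for this sharp loss on moving away from ethyl.

The compounds shown leave open how methyl, isopropyl or a straight propyl chain would fall on this scale, and so whether the number climbs gradually from ethyl to tert-butyl or jumps abruptly. They also leave open how a smaller nitrogen group, such as a simple amine or dimethylamino, would compare with diethylamino at this same position on the ring.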